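The source may report more compounds than this note shows. Statements on the series, on what has been measured and on what is new or still open speak of the compounds shown alone.

Working notes on the series. In a functional assay on HeLa cells (Homo sapiens) for inhibition, read by sulforhodamine B assay (on this read-out higher numbers stand for weaker inhibition and lower numbers for stronger inhibition), compound 3 `O=C1C=C(Nc2ccc(Br)cc2)C(=O)c2c1nc1n2[C@H]2OC[C@@H](O)[C@H]2OC1` gives 3830 nM, the lowest of the three numbers recorded, though each step to the others is within the scatter: compound 2 `CCc1ccc(NC2=CC(=O)c3nc4n(c3C2=O)[C@H]2OC[C@@H](O)[C@H]2OC4)cc1` gives 3990 nM and compound 1 `O=C1C=C(Nc2ccccc2F)C(=O)c2c1nc1n2[C@H]2OC[C@@H](O)[C@H]2OC1` gives 5120 nM. The steps of a 1.3-fold lower number from compound 1 to compound 2 (0.11 log units; within the scatter), a 1.3-fold lower number from compound 1 to compound 3 (0.13 log units; within the scatter) and a 1.0-fold lower number from compound 2 to compound 3 (0.02 log units; within the scatter) all concern the substituent on the phenyl ring and none reaches beyond the scatter.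

Compound 4 `O=C1C=C(N2CCCCC2)C(=O)c2c1nc1n2[C@H]2OC[C@@H](O)[C@H]2OC1` is the next point: piperidin-1-yl in place of (4-bromophenyl)amino on a double-bonded ring carbon. Within the data shown here, no measured step bears on this change, since every step so far kept an arylamino group in place; the measured steps offer no direction. Compound 4 is therefore expected to sit near the existing numbers with a wide range, at 7000 nM within 2000 nM to 25000 nM, an expected step of a 1.8-fold higher number from compound 3 to compound 4 (0.26 log units; within the scatter).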

Compound 4, half-maximal inhibitory concentration: > 16000 nM
Compound 4: a limit, no number (the forecaster's own chance of this, stated with the estimate: 15%); middle value at least 2.2-fold (0.35 log units) from the limit.
By their numbers in this assay, from the lowest: compounds 3, 2 and 1 (each within the scatter of the next). At a limit, above all of these: compound 4.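

Unlike the changes on the phenyl ring, all within the scatter, replacing the arylamino group on the double-bonded ring carbon moves the read-out beyond the scatter: an at least 4.1-fold higher number from compound 3 to compound 4 (0.62 log units; beyond the scatter) and an at least 4.0-fold higher number from compound 2 to compound 4 (0.60 log units; beyond the scatter) and an at least 3.1-fold higher number from compound 1 to compound 4 (0.49 log units; beyond the scatter). This position therefore tolerates less change than the phenyl substituents do, with piperidin-1-yl giving weaker inhibition than all three arylamino groups. In this assay compound 4 gives a limit and not a number: the limit of > 16000 nM in this assay, at which 1 of the 4 values shown sits.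

Compound 4 loses the amine hydrogen-bond donor and the aromatic ring together, so the compounds shown do not separate the two. As far as these compounds go, a cyclohexylamino group, which keeps the donor without the aromatic ring, remains open.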